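Emax notes on a cyclohexyl-ether series at the incretin receptor

The compounds below may be only part of what the source reports. "The series", "measured", "known", "first", "only" and "open" are said of these compounds alone.

Measured so far:
compound 1 `CC(C)OC(=O)N1CCC(O[C@H]2CC[C@H](Oc3cnc(S(C)(=O)=O)cn3)CC2)CC1` — 110%
compound 2 `CS(=O)(=O)c1cnc(O[C@H]2CC[C@H](OC3CCN(C(=O)OC4CCOC4)CC3)CC2)cn1` — 105%

In a functional assay on isolated protein for agonist activity at Glucose-dependent insulinotropic receptor (Homo sapiens), read by HTRF and cAMP accumulation (on this read-out higher numbers stand for larger maximal responses and lower numbers for smaller maximal responses), compound 1 gives 110% and compound 2 gives 105%. For the measured compounds named here, the only step known is a number 5 percentage points lower from compound 1 to compound 2 (within the scatter). On these two numbers compound 2 is the lower of the pair, but the gap to compound 1 lies within the scatter, so the two are treated as equivalent full responses.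

Compound 3 `CS(=O)(=O)c1cnc(O[C@H]2CC[C@H](OC3CCN(C(=O)C4(C(F)(F)F)CC4)CC3)CC2)cn1` is not yet measured. Its difference from compound 2: 1-(trifluoromethyl)cyclopropyl in place of (oxolan-3-yl)oxy on a carbonyl carbon. Going by the values given here, no measured step bears on this exchange; the one step known, from compound 1 to compound 2, alters a different part of the chain and stayed within the scatter. Without a step that speaks to this change, the expectation for compound 3 in this assay is 100% (range 80% to 115%), which is expected to mean a number 5 percentage points lower from compound 2 to compound 3 (within the scatter), a step not beyond the scatter.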

Compound 3, largest response reached (Emax), in percent of the reference or control that the assay uses: 107%
Compound 3: the middle estimate sits 7 percentage points below what was measured, and the stated range covers the measured number.
By their numbers in this assay, from the lowest: compounds 2, 3 and 1 (each within the scatter of the next).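

In this assay, putting 1-(trifluoromethyl)cyclopropyl on the carbonyl carbon in place of the oxygen-linked group gives a number 2 percentage points higher from compound 2 to compound 3 (within the scatter), and the same comparison against the isopropoxy group gives a number 3 percentage points lower from compound 1 to compound 3 (within the scatter). The earlier pair varied only the group on the oxygen, whereas these steps remove that oxygen from the carbonyl carbon, and the entering group has no hydrogen-bond acceptors, against 2 in (oxolan-3-yl)oxy. Across these three compounds, a full response therefore does not require an oxygen on this carbonyl carbon, and no available data explain why the response stays level.

From the compounds shown here alone, it remains open whether an amine, a carboxylic acid or a longer alkyl chain on this carbonyl carbon would keep the response in this assay. These maximal responses also leave open how the compounds compare in the concentration needed to reach them.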